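The source may report more compounds than this note shows. Statements on the series, on what has been measured and on what is new or still open speak of the compounds shown alone.

Measured compounds and their numbers in an assay on CHO cells for displacement of a labelled ligand from melatonin receptor type 1A (Homo sapiens), read by scintillation counting, with a stated time of 60 min; a lower number here means a stronger inhibitor, a higher number a weaker inhibitor:
compound 1 `COc1cccc(COc2ccc(OC)cc2CCCNC(C)=O)c1` gives 441 nM
compound 2 `COc1cc(CCCNC(C)=O)ccc1OCc1ccccc1` gives 8980 nM
compound 3 `CCC(=O)NCCCc1ccc(OCc2ccccc2)c(OC)c1` gives 2010 nM

Among these three, compound 2 carries the highest number in this assay; its nearest neighbour is compound 3, reached by a 4.5-fold lower number from compound 2 to compound 3 (0.65 log units; beyond the scatter). Compound 4 `COc1cccc(COc2ccc(CCCNC(C)=O)cc2OC)c1` differs from compound 2 by methoxy in place of hydrogen on an aromatic carbon. None of the measured steps bears directly on this change: the only listed step concerns the amide end of the chain, not the aromatic ring. Compound 1 also carries a 3-methoxyphenyl group, but on a differently arranged core, so its value is only a loose pointer. Compound 4 is therefore expected to move modestly, a 3.0-fold lower number from compound 2 to compound 4 (0.48 log units; beyond the scatter), giving an estimated 3000 nM with a range from 700 nM to 12000 nM.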

Compound 4, inhibition constant: 1460 nM
Estimate against measurement, compound 4: 2.1-fold (0.31 log units) above; low and high end bracket the measured number.
By their numbers in this assay, from the lowest: compound 1; then compounds 4 and 3 (each within the scatter of the next); then compound 2.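

Replacing phenyl with 3-methoxyphenyl gives a 6.2-fold lower number from compound 2 to compound 4 (0.79 log units; beyond the scatter) in this assay. Going by these compounds alone, the earlier step lay at the amide end of the chain, so this is the first sign that the number also responds to a change on the aromatic ring, here on an aromatic carbon meta to a large group. Nothing measured here accounts for this change.

Going by these compounds, it remains open whether a hydroxyl group or a chlorine atom in place of the methoxy would give a similar step. On these data alone, it is also open whether the methoxy step would hold alongside the propanamide of compound 3.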